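A few compounds are considered here, and "the series" means these few. Any claim that something is new, unique, unknown or untested is made for them only; others in the source may bear on it.

Measured so far: compound 1 `CSc1ccc(S(=O)(=O)NC(=O)Nc2ccc(Cl)cc2)s1` with 62%, compound 2 `CCc1ccc(S(=O)(=O)NC(=O)Nc2ccc(Cl)cc2)o1` with 80%, and compound 3 `CCc1ccsc1S(=O)(=O)NC(=O)Nc1ccc(Cl)cc1` with 25%, all in a functional assay on the whole organism (6C3HED cells, Mus musculus) for inhibition, at a dose of 300 mg/kg by the oral route; a higher number here means more inhibition at the dose given (going by the name of the read-out), a lower number less inhibition.

Compound 3 stands lowest of the three: compound 1 sits higher by a number 37 percentage points lower from compound 1 to compound 3 (beyond the scatter) read in reverse, and compound 2 higher still, as a number 55 percentage points lower from compound 2 to compound 3 (beyond the scatter) shows. Both gaps lie beyond the scatter, so the number for compound 3 is the lowest of the measured set.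

Compound 4 `O=C(Nc1ccc(Cl)cc1)NS(=O)(=O)c1cc(Br)c(Br)s1` is the next step from compound 3. Its change: 4,5-dibromothiophen-2-yl in place of 3-ethylthiophen-2-yl on a sulfonyl sulfur

Among the measured compounds shown here, no measured step swaps one substituted thiophene for another in this way, so the expectation rests on indirect evidence. Compound 1 also carries a thiophene, substituted away from the position used in compound 3. In this assay compound 1 gives 62%, well above compound 3. On these data alone, a return toward that level is therefore plausible, but the bromine substitution is untested here. Compound 4 is expected to rise by about a number 30 percentage points higher from compound 3 to compound 4 (beyond the scatter) in this assay, with wide uncertainty. The estimate for compound 4 is 55%, within a range of 25% to 85%.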

Compound 4, a percentage reported as inhibition, in the whole organism at one dose (the size of the read-out at that dose, not a potency): 52%
Estimate against measurement, compound 4: 3 percentage points above, within the range that was stated.
By their numbers in this assay, from the lowest: compound 3; then compounds 4 and 1 (each within the scatter of the next); then compound 2.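

In this assay, 4,5-dibromothiophen-2-yl on the sulfonyl sulfur in place of 3-ethylthiophen-2-yl gives a number 27 percentage points higher from compound 3 to compound 4 (beyond the scatter), which shows that the low number of compound 3 does not hold for every substituted thiophene at this place. Measured against the other two groups, the dibromothiophene gives a number 10 percentage points lower from compound 1 to compound 4 (within the scatter) and a number 28 percentage points lower from compound 2 to compound 4 (beyond the scatter), so two differently substituted thiophenes cannot be told apart here, while 5-ethylfuran-2-yl still gives the highest number of the set. Nothing measured alongside these numbers explains the differences between the groups.

The compounds shown leave open whether a single bromine on the thiophene would serve as well as two. They also leave open how 5-ethylthiophen-2-yl would compare with 5-ethylfuran-2-yl, and how a ring carrying an amine or a carboxylic acid would fare on the sulfonyl sulfur.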